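Swapping the Chain-End Amine Without a Firm Number

The source may report more compounds than this note shows. Statements on the series, on what has been measured and on what is new or still open speak of the compounds shown alone.

Within the data shown here, in a functional assay on HL-60 cells (Homo sapiens) for antiproliferative activity, read by MTT assay, with a stated time of 48 h (on this read-out lower numbers stand for stronger inhibition and higher numbers for weaker inhibition), none of the compounds measured so far gives an exact value. Compound 1 `CCn1c(N)c(-c2nc3ccccc3[nH]2)c2nc(C#N)c(C#N)nc21` reads > 50000 nM, which is a limit. Compound 2 `N#Cc1nc2c(-c3nc4ccccc4[nH]3)c(N)n(CCO)c2nc1C#N` reads > 50000 nM, also a limit. Compound 3 `CCN(CC)CCCn1c(N)c(-c2nc3ccccc3[nH]2)c2nc(C#N)c(C#N)nc21` reads > 730 nM, again a limit, so its position is only bounded. Compound 4 `CN1CCN(CCCn2c(N)c(-c3nc4ccccc4[nH]3)c3nc(C#N)c(C#N)nc32)CC1` changes one group of compound 3: 4-methylpiperazin-1-yl in place of diethylamino on a saturated chain carbon, three bonds along the chain from an aromatic nitrogen. In other words, 3-(diethylamino)propyl becomes 3-(4-methylpiperazin-1-yl)propyl. The closest evidence is a step that the two limits leave unreadable from compound 1 to compound 3 and a step that the two limits leave unreadable from compound 2 to compound 3, so no measured size carries over and no firm direction follows. The expected change, held only loosely, is a step that the limit leaves unreadable from compound 3 to compound 4. For compound 4, the estimated value is 4000 nM, with an expected range from 700 nM to 50000 nM.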

Compound 4, half-maximal inhibitory concentration: 750 nM
The estimate for compound 4 lay 5.3-fold (0.73 log units) above the measured number; the measured number falls inside the stated range.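

In this assay, compound 4 is the only compound shown with an exact value, so this position now has a firm reading. The 3-(4-methylpiperazin-1-yl)propyl group gives an at least 66-fold lower number from compound 1 to compound 4 (1.82 log units; beyond the scatter), and an at least 66-fold lower number from compound 2 to compound 4 (1.82 log units; beyond the scatter). The other steps cannot be read, and the swap of diethylamino for 4-methylpiperazin-1-yl has no size because compound 3 carries only a limit: the limit of > 730 nM in this assay, at which 1 of the 4 values shown sits.

Going by these compounds, whether the piperazine ring gives any gain over diethylamino therefore stays open. On these data alone, how a morpholin-4-yl group or a longer chain would read at this place also remains unknown.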